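Hydrazide series on breast cancer cells: fluoro to chloro

This account rests on a few compounds, and the source may have more. Where it says the series, first, only, none or still open, it means among the compounds named here.

Measured so far in a functional assay on MCF7 cells (Homo sapiens) for cytotoxicity, read by MTT assay, with a stated time of 48 h; on this read-out lower numbers stand for stronger inhibition and higher numbers for weaker inhibition:
compound 1 `Cn1cnc(C(=O)NNC(=O)COc2c(F)cc(C(=O)c3ccc(F)cc3)cc2Cl)c1` gives 45100 nM
compound 2 `Cn1cnc(C(=O)NNC(=O)COc2ccc(C(=O)c3ccccc3)cc2)c1` gives 30600 nM
compound 3 `O=C(COc1c(F)cc(C(=O)c2ccc(F)cc2)cc1Cl)NNC(=O)c1ccc(=O)oc1` gives 63200 nM

Compound 3 stands highest of the three numbers. Its nearest neighbour is compound 1, the step of a 1.4-fold higher number from compound 1 to compound 3 (0.15 log units; within the scatter) lying within the scatter; the gap to compound 2 is beyond the scatter.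

Compound 4 `O=C(COc1c(F)cc(C(=O)c2ccc(Cl)cc2)cc1Cl)NNC(=O)c1ccc(=O)oc1` differs from compound 3 by chloro in place of fluoro on an aromatic carbon.

For the measured compounds named here, no measured step bears on this change: the only step in hand, a 1.4-fold higher number from compound 1 to compound 3 (0.15 log units; within the scatter), exchanges a group on a carbonyl carbon of the shared core, not a halogen on the phenyl ring. The expectation is therefore no step beyond the scatter in this assay , estimated as a 1.1-fold lower number from compound 3 to compound 4 (0.02 log units; within the scatter). Compound 4 is expected at 60000 nM, within 25000 nM to 150000 nM.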

Compound 4, half-maximal inhibitory concentration: 86200 nM
Estimate against measurement, compound 4: 1.4-fold (0.16 log units) below; measured number inside the range.
By their numbers in this assay, from the lowest: compounds 2, 1, 3 and 4 (each within the scatter of the next, the first and the last beyond it).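

In this assay the change from 4-fluorophenyl to 4-chlorophenyl gives a 1.4-fold higher number from compound 3 to compound 4 (0.13 log units; within the scatter) and so does not separate the two halogens at this position. For the compounds shown here, compounds 1 and 3 both carry fluoro here, which makes this the first reading of a change at this site. No measured evidence on the compounds accounts for the step.

From the compounds shown here alone, whether an amine or a carboxylic acid in place of the halogen would give a step beyond the scatter stays open. So does whether chloro in place of fluoro reads the same on the core of compound 1.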